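Little Activity to Lose at the Aryl Triazole

A few compounds are considered here, and "the series" means these few. Any claim that something is new, unique, unknown or untested is made for them only; others in the source may bear on it.

In a functional assay on MDA-MB-231 cells (Homo sapiens) for antiproliferative activity, read by MTT assay, with a stated time of 48 h (a lower number here means a stronger inhibitor, a higher number a weaker inhibitor), compound 1 `COc1ccccc1-n1cc(COC(=O)/C(C)=C/CC/C(C)=C/CC/C(C)=C/CC[C@@H]2[C@@]3(C)CCC(=O)C(C)(C)[C@H]3CC[C@@]2(C)O)nn1` gives > 150000 nM, which is a limit of the assay and not a number. Within the data shown here, compound 2 `C/C(=C\CC/C(C)=C/CC[C@@H]1[C@@]2(C)CCC(=O)C(C)(C)[C@H]2CC[C@@]1(C)O)CC/C=C(\C)C(=O)OCc1cn(-c2cccc(F)c2)nn1` gives 144000 nM, the only true number available. Among the measured compounds shown here, the one measured step, an at least 1.0-fold lower number from compound 1 to compound 2 (0.01 log units; that floor lies within the scatter), replaced 2-methoxyphenyl with 3-fluorophenyl on an aromatic nitrogen, and it shows no change beyond the scatter.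

Compound 3 `C/C(=C\CC/C(C)=C/CC[C@@H]1[C@@]2(C)CCC(=O)C(C)(C)[C@H]2CC[C@@]1(C)O)CC/C=C(\C)C(=O)OCc1cn(-c2ccccc2Cl)nn1` keeps the shared core of compound 2 but carries 2-chlorophenyl in place of 3-fluorophenyl on that same aromatic nitrogen (2-chlorophenyl in place of 3-fluorophenyl on an aromatic nitrogen). For the measured compounds named here, the only measured exchange at this place gives no sign that a new group there moves the result much, and the expectation therefore starts from compound 2 at 144000 nM. No step beyond the scatter is expected in this assay, and the estimated change is a 1.2-fold lower number from compound 2 to compound 3 (0.08 log units; within the scatter). A reading at the assay limit would also fit this expectation. For compound 3, the expected value is 120000 nM, with an estimated range of 60000 nM to 190000 nM.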

Compound 3, half-maximal inhibitory concentration: > 150000 nM
Compound 3 ended at the assay's limit; the forecaster's own chance of this, stated with the estimate: 35%; middle value at least 1.2-fold (0.09 log units) away from the limit.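

The exchange of 3-fluorophenyl for 2-chlorophenyl gives a second step at this aromatic nitrogen in this assay, an at least 1.0-fold higher number from compound 2 to compound 3 (0.01 log units; that floor lies within the scatter), and the limit fixes only that floor and not the true size of the step. Compound 3 gives > 150000 nM, which is a limit of the assay and not a number. Three different aryl groups have now been tried at this position, and none brings the reading clear of the top of the tested range: the limit of > 150000 nM in this assay, at which 2 of the 3 values shown sit.

The step from compound 1 to compound 3, chloro in place of methoxy, cannot be read, as both values are limits, so the 2-chlorophenyl and 2-methoxyphenyl groups cannot be ranked against each other. As far as these compounds go, it remains open whether an amine or a carboxylic acid on the phenyl ring would give a clearly lower number in this assay, or whether this position can move the result at all.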